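Alkyl swap on the aromatic core of a diamine series

The compounds below may be only part of what the source reports. "The series", "measured", "known", "first", "only" and "open" are said of these compounds alone.

Three compounds have been measured in a physicochemical assay for acid dissociation:

compound 1 `CC(C)Cc1ccc2c(NCCCNCc3ccco3)ccnc2c1` gives 9.47
compound 2 `COc1ccc(F)cc1CNCCCNc1ccnc2cc(CC(C)C)ccc12` gives 9.47
compound 3 `COc1cccc(CNCCCNc2ccnc3cc(Cc4ccc(C#N)cc4)ccc23)c1O` gives 9.47

Compound 2 stands level with compound 1 and compound 3 at the digits shown; its nearest neighbour is compound 1 and its furthest compound 3, and neither gap exceeds the scatter. Among the measured compounds shown here, the one measured step, no change at the digits printed from compound 1 to compound 2 (within the scatter), replaced the group on a saturated chain carbon bound to an amine nitrogen and left the value unchanged.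

Compound 4 `CCC(CC)c1ccc2c(NCCCNCc3cc(F)ccc3OC)ccnc2c1` differs from compound 2 by pentan-3-yl in place of isobutyl on an aromatic carbon. For the measured compounds named here, no measured step alters the group on that aromatic carbon, so the prediction rests on the flat picture seen across compounds 1 to 3. Compound 4 is expected to show no step beyond the scatter, no change at the digits printed from compound 2 to compound 4 (within the scatter). Compound 4 is estimated at 9.47, within 9.17 to 9.77.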

Compound 4, acid dissociation constant: 9.47
For compound 4 middle estimate and measured number coincide at the digits printed; measured number inside the range.
By their numbers in this assay, from the lowest: compounds 1, 2, 3 and 4 (each within the scatter of the next).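

In this assay, the aromatic carbon of the shared core now has a measured step of its own: pentan-3-yl in place of isobutyl, one carbon larger, gives no change at the digits printed from compound 2 to compound 4 (within the scatter). So this alkyl swap at this position, like the earlier change on the saturated chain carbon, leaves the read-out unmoved. Nothing available explains this flatness. The compounds shown leave open whether an amine or a carboxylic acid on this aromatic carbon would shift the value beyond the scatter.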